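Removing the branch methyl: compound 3 to compound 4

A few compounds are considered here, and "the series" means these few. Any claim that something is new, unique, unknown or untested is made for them only; others in the source may bear on it.

In a functional assay on HEK293 cells for agonist activity at G-protein coupled receptor 84 (Homo sapiens), read by calcium flux (a higher number here means a larger maximal response, a lower number a smaller maximal response), compound 3 `CCCCCCCC(C)c1nc(O)cc(O)n1` gives 103%. That places compound 3 level with compound 1 `CCCCCCCc1nc(O)cc(O)n1`, which in this assay gives 103%, with no change between the two as the numbers stand, and both sit above compound 2 `CCCCCCCCCc1nc(O)cc(O)n1`, which gives 84.1%; compound 3 reads higher than compound 2, a gap beyond the scatter.

Compound 4 `CCCCCCCCc1nc(O)cc(O)n1` differs from compound 3 by hydrogen in place of methyl on a saturated chain carbon bound to an aromatic carbon and a saturated chain carbon. Going by the values given here, the only measured step in this set is a number 18.9 percentage points lower from compound 1 to compound 2 (beyond the scatter), a modest fall for lengthening the chain. Among the compounds with values here, no measured step addresses taking a methyl off the saturated chain carbon bound to the aromatic carbon, so the loss of that branch itself cannot be read from the data. What can be said is that compound 4 carries a chain of a length between that of compound 1 and that of compound 2, whose values bracket the likely outcome.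

Compound 4 is therefore expected to give about 95% in this assay, within 80% to 108%. The step expected from compound 3 is a number 8 percentage points lower from compound 3 to compound 4 (within the scatter), small and within the scatter.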

Compound 4, largest response reached (reported as percent of maximum), in percent of the reference or control that the assay uses: 110%
Beside the measured number, compound 4's estimate is 15 percentage points below it; measured number outside the range, above it.
By their numbers in this assay, from the lowest: compound 2; then compounds 1, 3 and 4 (each within the scatter of the next).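

Replacing the methyl with hydrogen on the saturated chain carbon bound to an aromatic carbon leaves this assay essentially unchanged, with a number 7 percentage points higher from compound 3 to compound 4 (within the scatter) as the step, so the branch at this position is not required for a full response. Set against the unbranched chains, the result narrows where the loss of response begins: the reading shows a number 7 percentage points higher from compound 1 to compound 4 (within the scatter) as the step, whereas the other comparison gives a number 25.9 percentage points higher from compound 2 to compound 4 (beyond the scatter) as a step beyond the scatter. Among the compounds shown, compound 2 alone therefore stands apart from the rest, and the fall in response appears only with its longer chain rather than gradually along the series, while nothing in the available evidence accounts for this.

On these data alone, what a hydroxyl or an amine on this same chain carbon would do remains open, as does whether a chain longer than that of compound 2 would lower the response further. The largest response also does not tell how much of each compound is needed to reach it.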